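Furan-2-yl for benzofuran-2-yl on two nucleoside cores

A few compounds are considered here, and "the series" means these few. Any claim that something is new, unique, unknown or untested is made for them only; others in the source may bear on it.

Measured so far in a functional assay on A549 cells (Homo sapiens), read by MTT assay, with a stated time of 72 h; a higher number here means a weaker inhibitor, a lower number a stronger inhibitor:
compound 1, `O=c1[nH]cnc2c1c(-c1ccco1)cn2[C@@H]1O[C@H](CO)[C@@H](O)[C@H]1O`, gives > 20000 nM, a limit of the assay.
Compound 2, `O=c1[nH]cnc2c1c(-c1cc3ccccc3o1)cn2[C@@H]1O[C@H](CO)[C@@H](O)[C@H]1O`, gives > 20000 nM, also a limit.
Compound 3, `Nc1nc(N)c2c(-c3cc4ccccc4o3)cn([C@@H]3O[C@H](CO)[C@@H](O)[C@H]3O)c2n1`, gives > 20000 nM, again a limit.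

The step from compound 2 to compound 1 is furan-2-yl in place of 1-benzofuran-2-yl on an aromatic carbon; its size in this assay is a step that the two limits leave unreadable from compound 2 to compound 1, unreadable because of the limit of > 20000 nM in this assay, at which 3 of the 3 values shown sit. Compound 3 carries a different core from compound 2; the difference between the two cores is not broken down here. Compound 4, `Nc1nc(N)c2c(-c3ccco3)cn([C@@H]3O[C@H](CO)[C@@H](O)[C@H]3O)c2n1`, is not yet measured and stands to compound 3 as furan-2-yl in place of 1-benzofuran-2-yl on an aromatic carbon, the same change as that from compound 2 to compound 1.

For compound 4 in this assay the expected step is a step that the limit leaves unreadable from compound 3 to compound 4, resting on compound 3 and its value > 20000 nM. The estimate for compound 4 is 30000 nM, with a range of 15000 nM to 100000 nM; a further limit is expected.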

Compound 4, half-maximal inhibitory concentration: > 20000 nM
Compound 4: no number, only a limit; the forecaster's own chance of this, stated with the estimate: 90%; the middle value does not contradict the limit.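

In this assay compound 4 gives > 20000 nM, a limit, and no step can be read between compound 3 and compound 4: the limit of > 20000 nM in this assay, at which 4 of the 4 values shown sit.

The compounds shown leave open how furan-2-yl and 1-benzofuran-2-yl compare on either core.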